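A Fluoro Added to a Trifluoromethyl-Bearing Aryl Enone

The compounds below may be only part of what the source reports. "The series", "measured", "known", "first", "only" and "open" are said of these compounds alone.

In a functional assay on PC-3 cells (Homo sapiens) for cytotoxicity, read by MTT assay, with a stated time of 72 h (on this read-out higher numbers stand for weaker inhibition and lower numbers for stronger inhibition), three compounds have been measured so far:

compound 1 `COc1ccc(/C=C/C(=O)/C=C/C2=C(C)CCCC2(C)C)cc1OC`: 42000 nM
compound 2 `CC1=CCCC(C)(C)C1/C=C/C(=O)/C=C/c1ccccc1C(F)(F)F`: 19000 nM
compound 3 `CC1=CCCC(C)(C)C1/C=C/C(=O)/C=C/c1cccc(C(F)(F)F)c1`: 5200 nM

Compound 3 stands lowest of the three numbers; its gap to compound 2 and its wider gap to compound 1 both lie beyond the usual scatter, so compound 3 is the strongest inhibitor shown here. Compound 4 `CC1=CCCC(C)(C)C1/C=C/C(=O)/C=C/c1cc(C(F)(F)F)ccc1F` differs from compound 3 in one place: fluoro in place of hydrogen on an aromatic carbon. Going by the values given here, no measured pair shows this kind of change, so nothing in these data tells how large a step it brings. For compound 4 the expected step of a 1.3-fold lower number from compound 3 to compound 4 (0.11 log units; within the scatter) is therefore kept small and would not clearly exceed the scatter in either direction. Compound 4 is estimated at 4000 nM, within a range from 1500 nM to 11000 nM.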

Compound 4, half-maximal inhibitory concentration: 3100 nM
For compound 4 the middle estimate is 1.3-fold (0.11 log units) above the measured one; the measured number falls inside the stated range.
By their numbers in this assay, from the lowest: compounds 4 and 3 (each within the scatter of the next); then compound 2; then compound 1.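

Going by these compounds alone, this is the first measured step for fluoro in place of hydrogen on an aromatic carbon, here ortho to a large group and para to a trifluoromethyl group. In this assay the change gives a 1.7-fold lower number from compound 3 to compound 4 (0.22 log units; within the scatter) and so does not separate the two compounds at this position. No measurement shown explains the size of this step. Still open, on these data alone, is whether a chlorine atom or an amine on the same carbon would give a step beyond the scatter.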